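Anilide to Benzylamide at the Hydroxamate Scaffold

The compounds below may be only part of what the source reports. "The series", "measured", "known", "first", "only" and "open" are said of these compounds alone.

Three compounds have been measured in a functional assay on SK-N-AS cells (Homo sapiens) for antiproliferative activity, with a stated time of 72 h; on this read-out lower numbers stand for stronger inhibition and higher numbers for weaker inhibition:

compound 1, `Cc1ccc(NC(=O)CCN(Cc2ccc(C(=O)NO)cc2)C(=O)c2cc(C)cc(C)c2)cc1`, gives 220 nM;
compound 2, `Cc1ccc(NC(=O)CCN(Cc2ccc(C(=O)NO)cc2)C(=O)c2ccc(N(C)C)cc2)cc1`, gives 400 nM;
compound 3, `Cc1ccc(NC(=O)CCN(Cc2ccc(C(=O)NO)cc2)C(=O)c2ccccc2)cc1`, gives 620 nM.

Compound 2 stands second highest of the three numbers. Its nearest neighbour is compound 3, with a 1.6-fold higher number from compound 2 to compound 3 (0.19 log units; within the scatter), and its furthest is compound 1, with a 1.8-fold higher number from compound 1 to compound 2 (0.26 log units; within the scatter). Within the data shown here, the only step beyond the scatter in this set is a 2.8-fold higher number from compound 1 to compound 3 (0.45 log units; beyond the scatter), and all three steps concern the group on the carbonyl carbon.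

Compound 4, `Cc1ccc(CNC(=O)CCN(Cc2ccc(C(=O)NO)cc2)C(=O)c2ccc(N(C)C)cc2)cc1`, differs from compound 2 at a different place: 4-methylbenzyl in place of 4-methylphenyl on an amide-type nitrogen. Among the measured compounds shown here, none of the measured steps touches the amide-type nitrogen, so no measured step bears on this change, and nothing in the data sets its direction. The expectation for compound 4 is therefore a step of about no change at the digits printed from compound 2 to compound 4 (within the scatter), that is, no step beyond the scatter. Compound 4 is estimated at 400 nM, within a range of 130 nM to 1200 nM.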

Compound 4, half-maximal inhibitory concentration: 340 nM
Beside the measured number, compound 4's estimate is 1.2-fold (0.07 log units) above it; the measured number falls inside the stated range.
By their numbers in this assay, from the lowest: compounds 1, 4, 2 and 3 (each within the scatter of the next, the first and the last beyond it).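

In this assay, the first change shown at the amide-type nitrogen, 4-methylbenzyl in place of 4-methylphenyl, gives a 1.2-fold lower number from compound 2 to compound 4 (0.07 log units; within the scatter) and so leaves the number where it was. For this pair, which carries the 4-(dimethylamino)phenyl group on the carbonyl carbon, going from 7 to 8 heavy atoms at this position, with the same six-membered aromatic ring, does not move the read-out beyond the scatter. No supporting measurement bears on this result or accounts for it.

Going by these compounds, whether the same change would also stay within the scatter with 3,5-dimethylphenyl or phenyl on the carbonyl carbon remains open. Also open, on these data alone, is how a longer chain such as 2-(4-methylphenyl)ethyl, or a benzyl group carrying an amine or a carboxylic acid, would read at this nitrogen.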